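Extending the alkyl chain on the furan substituent

A few compounds are considered here, and "the series" means these few. Any claim that something is new, unique, unknown or untested is made for them only; others in the source may bear on it.

Compound 1 `CC[C@@H](Nc1c(Nc2cccc(C(=O)N(C)C)c2O)c(=O)c1=O)c1cc(C)co1` and compound 2 `CCC(C)c1coc([C@@H](CC)Nc2c(Nc3cccc(C(=O)N(C)C)c3O)c(=O)c2=O)c1` share one core and differ only on the furan ring, where compound 2 carries sec-butyl in place of methyl on an aromatic carbon. In an assay on CHO cells for displacement of a labelled ligand from C-X-C chemokine receptor type 1 (Homo sapiens) (a higher number here means a weaker inhibitor, a lower number a stronger inhibitor), compound 1 gives 9 nM and compound 2 gives 7.6 nM. The step of a 1.2-fold lower number from compound 1 to compound 2 (0.07 log units; within the scatter) shows that this replacement is not resolved by this assay. Among the compounds with values here, compound 2 holds the lower of the two numbers measured so far, but its gap to compound 1 lies within the scatter, so no order between them can be read. Compound 3 `CCC(CC)c1coc([C@@H](CC)Nc2c(Nc3cccc(C(=O)N(C)C)c3O)c(=O)c2=O)c1` continues the same line of substitution: methyl in place of hydrogen on a saturated chain carbon, two bonds along the chain from an aromatic carbon. Within the data shown here, only the step from compound 1 to compound 2 bears on this change, and it was within the scatter; nothing in the data separates the alkyl groups on that furan carbon from one another. The added methyl is therefore expected to leave the number near that of compound 2, and the expected step is a 1.0-fold lower number from compound 2 to compound 3 (0.01 log units; within the scatter). For compound 3 the estimate in this assay is 7.5 nM, with a range from 3 nM to 18 nM.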

Compound 3, inhibition constant: 30 nM
For compound 3 the middle estimate is 4.0-fold (0.60 log units) below the measured one; measured number outside the range, above it.
By their numbers in this assay, from the lowest: compounds 2 and 1 (each within the scatter of the next); then compound 3.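

In this assay the alkyl group on this furan carbon now registers, with a 3.9-fold higher number from compound 2 to compound 3 (0.60 log units; beyond the scatter) for methyl in place of hydrogen on a saturated chain carbon, two bonds along the chain from an aromatic carbon; sec-butyl to pentan-3-yl therefore counts here, although methyl to sec-butyl could not be resolved. Pentan-3-yl also separates from the smaller methyl, with a 3.3-fold higher number from compound 1 to compound 3 (0.52 log units; beyond the scatter) as the second modest step, so across these three compounds the number stays within the scatter from methyl to sec-butyl and rises only with pentan-3-yl, which sets a first limit on this substituent in this series, resting on a single added methyl. Nothing available bears on why the number rises at this change.

Open, going by these compounds, is whether the rise follows the size of the group or the branching on its first carbon, a question that a straight chain such as n-pentyl or a ring such as cyclopentyl on the same furan carbon would address. Also open, on these data alone, is whether a longer branched chain such as heptan-4-yl raises the number further, or whether an ether oxygen or an amine within the chain changes the picture.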